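The source may hold more compounds than are shown below. What is called first, only, known or untested is meant among the compounds shown, and "the series" means these compounds.

Of the compounds shown here, three built on one shared core have been tested in an assay on membranes from HEK293 cells for displacement of a labelled ligand from adenosine receptor A2b (Homo sapiens), read by scintillation counting, with a stated time of 30 min, tested at 1 uM; a higher number here means more inhibition at the concentration tested (going by the name of the read-out), a lower number less inhibition. Compound 1 `CC1=C(C(=O)C2CC2)C(c2ccsc2)NC(=O)N1` gives 1%, compound 2 `CCN(CC)C(=O)C1=C(C)NC(=O)NC1c1ccco1` gives 31%, and compound 3 `CC1=C(C(N)=O)C(c2ccsc2)NC(=O)N1` gives 1%. Compound 3 thus stands level with compound 1 at the digits shown, the two together forming the bottom of the set, while compound 2 sits a number higher that lies beyond the scatter. Among the measured compounds shown here, the only measured single-point step, no change at the digits printed from compound 1 to compound 3 (within the scatter), shows that exchanging one group on the carbonyl carbon for another left the read-out unchanged.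

Compound 4 `CCN(CC)C(=O)C1=C(C)NC(=O)NC1c1ccsc1` differs from compound 3 in that (diethylamino in place of amino on a carbonyl carbon). For the measured compounds named here, no measured step covers this exact swap, so the step from compound 1 to compound 3 is only a loose guide. Going by the values given here, compound 2 also carries a diethylamino group on its carbonyl carbon and gives a number above compound 3 that lies beyond the scatter, though its ring is not the one in compound 4, so only its value can be read. On that basis compound 4 is expected to give 20%, between 2% and 40%. The expected change is a number 19 percentage points higher from compound 3 to compound 4 (beyond the scatter).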

Compound 4, a percentage reported as inhibition, at one concentration (the size of the read-out at that concentration, not a potency): 11%
For compound 4 the middle estimate is 9 percentage points above the measured one; measured number inside the range.
By their numbers in this assay, from the lowest: compounds 1, 3 and 4 (each within the scatter of the next); then compound 2.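

In this assay, diethylamino in place of amino on a carbonyl carbon gives a number 10 percentage points higher from compound 3 to compound 4 (within the scatter), and diethylamino in place of cyclopropyl gives a number 10 percentage points higher from compound 1 to compound 4 (within the scatter), so with thiophen-3-yl on the saturated ring carbon, this carbonyl position shows no difference that can be told from the scatter. Thiophen-3-yl in place of furan-2-yl on a saturated ring carbon, with diethylamino kept, gives a number 20 percentage points lower from compound 2 to compound 4 (beyond the scatter), the first single-place step here that lies beyond the scatter, so diethylamino alone does not carry the higher number of compound 2. Nothing measured here gives a cause for either result.

Still open, as far as these compounds go, is whether furan-2-yl gives a higher number with amino or cyclopropyl on the carbonyl carbon as well. From the compounds shown here alone, how a phenyl ring on the saturated ring carbon, or a dipropylamino group on the carbonyl carbon, would read also remains open.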